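The compounds below may be only part of what the source reports. "The series", "measured", "known", "first", "only" and "open" are said of these compounds alone.

Compound 1, with the structure `CCCc1cc(C(C)=O)c(O)cc1OCCCCC#N`, stands second of the three measured compounds in an assay on isolated protein for inhibition of leukotriene B4 receptor 1 (Homo sapiens), tested at 10 uM (a lower number here means less inhibition, a higher number more inhibition at the concentration tested (going by the name of the read-out)), where compound 1 gives 84%. Compound 2, `CCc1cc(C(C)=O)c(O)cc1OCCCCCCC#N`, gives 103% in this assay, and compound 3, `CC(=O)c1cc(CO)c(OCCCCCCC#N)cc1O`, gives 40%. The step from compound 1 to compound 4, whose structure is `CC(=O)c1cc(CC(C)O)c(OCCCCC#N)cc1O`, consists of hydroxy in place of hydrogen on a saturated chain carbon bound to two saturated chain carbons. For the measured compounds named here, the only measured step that bears on it is the one between compound 2 and compound 3, which also introduces a hydroxy onto a saturated chain carbon and reads a number 63 percentage points lower from compound 2 to compound 3 (beyond the scatter). In compound 4 the hydroxy sits one bond further from the aromatic carbon, so the loss in this assay is expected to be smaller but still in the same direction. Compound 4 is therefore expected to show a number 34 percentage points lower from compound 1 to compound 4 (beyond the scatter), because the drop a number 63 percentage points lower from compound 2 to compound 3 (beyond the scatter) shows that a hydroxy on a saturated chain carbon cost much. Compound 4 is estimated to reach 50% in this assay, within a range from 20% to 80%.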

Compound 4, a percentage reported as inhibition, at one concentration (the size of the read-out at that concentration, not a potency): 10%
Compound 4: middle estimate off by 40 percentage points, on the high side; measured number below the stated range.
By their numbers in this assay, from the lowest: compound 4; then compound 3; then compound 1; then compound 2.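

Moving the hydroxy onto a saturated chain carbon bound to two saturated chain carbons, as in propyl to 2-hydroxypropyl, does not spare the compound in this assay: the reading is a number 74 percentage points lower from compound 1 to compound 4 (beyond the scatter), a large step. The earlier step, a number 63 percentage points lower from compound 2 to compound 3 (beyond the scatter), placed the hydroxy on a carbon bound to an aromatic carbon and was also large, so across these two pairs a large loss accompanies the hydroxy at both places. Nothing available explains why this hydroxy lowers the inhibition so strongly.

The compounds shown leave open whether a methoxy or an amine on this same carbon would read like the hydroxy. They also leave open whether a hydroxy carried on a longer chain would bring a loss of this size.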